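Swapping a Heteroaromatic Ring Beside the Acid Chain

The source may report more compounds than this note shows. Statements on the series, on what has been measured and on what is new or still open speak of the compounds shown alone.

Compound 2 `Cc1nc(-c2ccc(C(F)(F)F)cc2)sc1COc1ccc([C@H](CC(=O)O)c2nccn2C)cc1` is one of two compounds tested in an assay on CHO cells for agonist activity at Free fatty acid receptor 1 (Homo sapiens), read by calcium flux; on this read-out higher numbers stand for an effect only at larger amounts of compound and lower numbers for an effect already at smaller amounts; compound 2 gives 73 nM, the higher of the two numbers, while compound 1 `Cc1cc(Cl)ccc1-c1cccc(COc2ccc([C@H](CC(=O)O)c3nccn3C)cc2)c1` gives 33 nM, a difference beyond the usual scatter. Compound 3 `Cc1nc(-c2ccc(C(F)(F)F)cc2)sc1COc1ccc([C@H](CC(=O)O)c2ncnn2C)cc1` keeps the core of compound 2 and differs only in the change (1-methyl-1H-1,2,4-triazol-5-yl in place of 1-methyl-1H-imidazol-2-yl on a saturated chain carbon bound to an aromatic carbon and a saturated chain carbon). Going by the values given here, no measured pair shows the effect of this change, so the step from compound 2 to compound 3 in this assay is expected to be small, within the scatter, in either direction a 1.4-fold higher number from compound 2 to compound 3 (0.14 log units; within the scatter). Compound 3 is therefore estimated at 100 nM, with a range from 35 nM to 300 nM.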

Compound 3, half-maximal effective concentration: 65 nM
Beside the measured number, compound 3's estimate is 1.5-fold (0.19 log units) above it, and the stated range covers the measured number.
By their numbers in this assay, from the lowest: compounds 1, 3 and 2 (each within the scatter of the next, the first and the last beyond it).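

In this assay, 1-methyl-1H-1,2,4-triazol-5-yl in place of 1-methyl-1H-imidazol-2-yl gives a 1.1-fold lower number from compound 2 to compound 3 (0.05 log units; within the scatter). This first measured step at this position shows that, on the core of compound 2, a five-membered aromatic ring with 3 hetero atoms reads the same as one with 2. Nothing measured here explains this match. Going by these compounds, whether the same swap holds on the core of compound 1 stays open. So does the outcome of placing a different group here, such as a primary amide or a pyridine ring.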